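This account rests on a few compounds, and the source may have more. Where it says the series, first, only, none or still open, it means among the compounds named here.

Values in a functional assay on DU-145 cells (Homo sapiens) for antiproliferative activity, read by sulforhodamine B assay, with a stated time of 48 h (on this read-out lower numbers stand for stronger inhibition of growth and higher numbers for weaker inhibition of growth), so far:

compound 1 `CNc1nc(Nc2ccc(OC)cc2)nc2ccccc12`: 14300 nM
compound 2 `COc1ccc(N(C)c2nc(NC3CCCC3)c3ccccc3n2)cc1`: 10200 nM
compound 3 `COc1ccc(N(C)c2nc(NCCCO)c3ccccc3n2)cc1`: 30200 nM

Compound 3 gives the highest number of the three, beyond the scatter from both others. Among the compounds with values here, the one step on the same nitrogen, a 3.0-fold higher number from compound 2 to compound 3 (0.47 log units; beyond the scatter), shows the 3-hydroxypropyl group costing potency against cyclopentyl. Compound 4 `CNc1nc(N(C)c2ccc(OC)cc2)nc2ccccc12` differs from compound 3 by hydrogen in place of 2-hydroxyethyl on a saturated chain carbon bound to a nitrogen on an aromatic ring. Within the data shown here, only that step bears on the change, and not directly, since methyl is shorter still. Compound 1, which carries methylamino on the same nitrogen, sits between compound 2 and compound 3 on the numbers, so a return toward that region is expected: a 1.8-fold lower number from compound 3 to compound 4 (0.25 log units; within the scatter), a modest step down. Compound 4 is estimated at 17000 nM, range 7000 nM to 45000 nM.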

Compound 4, concentration for 50% growth inhibition: 24300 nM
Compound 4: the middle estimate sits 1.4-fold (0.16 log units) below what was measured; low and high end bracket the measured number.
By their numbers in this assay, from the lowest: compounds 2, 1, 4 and 3 (each within the scatter of the next, the first and the last beyond it).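

In this assay, removing the 2-hydroxyethyl part leaves the number within the scatter (a 1.2-fold lower number from compound 3 to compound 4 (0.09 log units; within the scatter)), so methylamino and (3-hydroxypropyl)amino cannot be told apart here, and the hydroxyl-bearing chain is not singled out as the cost. Cyclopentyl alone separates, with methyl in its place giving a step beyond the scatter (a 2.4-fold higher number from compound 2 to compound 4 (0.38 log units; beyond the scatter)), while methyl in place of hydrogen on a nitrogen on an aromatic ring stays within it (a 1.7-fold higher number from compound 1 to compound 4 (0.23 log units; within the scatter)). No measured evidence bears on the reason for these steps.

Open, going by these compounds, is whether a cyclohexyl ring or a longer unbranched alkyl chain on this nitrogen matches cyclopentyl. A terminal amine or carboxylic acid on the chain also remains untested among the compounds shown.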